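The compounds below may be only part of what the source reports. "The series", "measured", "known", "first", "only" and "open" are said of these compounds alone.

Measured in a functional assay on MDA-MB-435 cells (Homo sapiens) for cytotoxicity, read by MTT assay, with a stated time of 72 h; a lower number here means a stronger inhibitor, a higher number a weaker inhibitor:
- Compound 1 `CS(=O)(=O)Oc1c(C(=O)NCc2ccc(F)cc2)nc(Br)c2cccnc12`: > 20000 nM, a limit of the assay
- Compound 2 `O=C(NCc1ccc(F)cc1)c1nc(NCCO)c2cccnc2c1O`: > 20000 nM, a limit of the assay
- Compound 3 `COc1cccc(CNC(=O)c2nc(Br)c3cccnc3c2N[C@H]2CC[C@H](N)CC2)c1`: 7000 nM

Compound 1 and compound 2 both stand at the limit of > 20000 nM in this assay, at which 2 of the 3 values shown sit. Only compound 3 has an actual number, 7000 nM, which makes it the sole starting point in this assay.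

Compound 4 `N[C@H]1CC[C@H](Nc2c(C(=O)NCc3ccc(Cl)cc3Cl)nc(Br)c3cccnc23)CC1` keeps the rest of compound 3 and changes one group: 2,4-dichlorophenyl in place of 3-methoxyphenyl on a saturated chain carbon bound to an amide-type nitrogen. In words, 2,4-dichlorophenyl replaces 3-methoxyphenyl on a saturated chain carbon bound to an amide-type nitrogen.

For the measured compounds named here, no measured pair shows the effect of this swap, so only a modest shift toward stronger inhibition is expected. The expected change is a 1.8-fold lower number from compound 3 to compound 4 (0.24 log units; within the scatter), which may not clear the usual scatter. For compound 4 the estimated value is 4000 nM, with an expected range of 1000 nM to 15000 nM.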

Compound 4, half-maximal inhibitory concentration: 5800 nM
Beside the measured number, compound 4's estimate is 1.5-fold (0.16 log units) below it, within the range that was stated.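

In this assay, the swap gives a 1.2-fold lower number from compound 3 to compound 4 (0.08 log units; within the scatter), the first step shown between two compounds differing in one place. On this saturated chain carbon, 2,4-dichlorophenyl and 3-methoxyphenyl therefore cannot be told apart, even though the two rings carry different substituents. Nothing measured here explains why the two rings read alike. Still open, as far as these compounds go, is whether a ring bearing a carboxylic acid or an amine would read differently at this place. A longer chain between the amide-type nitrogen and the ring also remains untested among the compounds shown.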